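From Amide Benzyl to Dimethylphenyl on a Weak Series

The source may hold more compounds than are shown below. What is called first, only, known or untested is meant among the compounds shown, and "the series" means these compounds.

Measured compounds:
compound 1, `COc1ccc(CNC(=O)/C=C/c2coc3cc(O)ccc3c2=O)cc1`, 10000 nM
compound 2, `O=C(/C=C/c1coc2cc(O)ccc2c1=O)NCc1ccccc1`, 63000 nM
compound 3, `COc1ccc2c(=O)c(/C=C/C(=O)NCc3ccccc3)coc2c1`, a limit only in the assay described below

The three compounds share one core and were tested in a functional assay (QGY7701 cells, Homo sapiens) for inhibition, read by MTT assay, with a stated time of 48 h; on this read-out higher numbers stand for weaker inhibition and lower numbers for stronger inhibition. In this assay compound 3 reaches only the limit > 100000 nM; the value stands at the limit of > 100000 nM in this assay, at which 1 of the 3 values shown sits. The two steps that were measured both touch the hydroxy or methoxy position of the core: a 6.3-fold higher number from compound 1 to compound 2 (0.80 log units; beyond the scatter), and an at least 1.5-fold higher number from compound 2 to compound 3 (0.20 log units; that floor lies within the scatter).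

Compound 4, `COc1ccc2c(=O)c(/C=C/C(=O)Nc3cc(C)ccc3C)coc2c1`, differs from compound 3 at the amide nitrogen: 2,5-dimethylphenyl in place of benzyl on an amide-type nitrogen. Neither measured step concerns the group on the amide-type nitrogen, so the change from compound 3 to compound 4 has no direct precedent among these compounds; the starting point is a limit rather than a number. The author therefore expects compound 4 to remain near the limit, with a number no higher from compound 3 to compound 4 (the limit leaves the size open) amounting to no clear movement. Compound 4 is estimated at 100000 nM, between 30000 nM and 300000 nM, with a limit the most likely report.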

Compound 4, half-maximal inhibitory concentration: > 100000 nM
Compound 4 was reported as a limit; the forecaster's own chance of this, stated with the estimate: 70%; the middle value lies on the limit itself.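

In this assay compound 3 gives > 100000 nM, a limit and not a number. Among these compounds, compound 4 gives > 100000 nM, again a limit, so no step between compound 3 and compound 4 can be read. The compounds shown leave open how 2,5-dimethylphenyl in place of benzyl on the amide-type nitrogen acts on a core that gives a measurable number.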